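Removing a Hydroxy Group from Compound 3

A few compounds are considered here, and "the series" means these few. Any claim that something is new, unique, unknown or untested is made for them only; others in the source may bear on it.

In an ADME assay on HepG2 cells (Homo sapiens) for cytotoxicity, read by MTT assay, with a stated time of 24 h (on this read-out higher numbers stand for lower toxicity in this test and lower numbers for higher toxicity in this test), compound 1 `CCCOc1ccc(-c2c([N+](=O)[O-])nc3n2CC(C)O3)cc1` reaches only a limit, > 62500 nM. Two relatives give actual numbers: compound 2 `Cc1ccc(C#Cc2c([N+](=O)[O-])nc3n2CC(C)O3)cc1` gives 4440 nM, and compound 3 `CC1Cn2c(nc([N+](=O)[O-])c2C#Cc2ccc(CO)cc2)O1` gives 9000 nM, the higher of the two. The step between them places hydroxy in place of hydrogen on a saturated chain carbon bound to an aromatic carbon, and it is modest: a 2.0-fold higher number from compound 2 to compound 3 (0.31 log units; beyond the scatter).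

Compound 4 `CC1Cn2c(nc([N+](=O)[O-])c2C#Cc2ccc(C(C)(C)C)cc2)O1` has tert-butyl in place of hydroxymethyl on an aromatic carbon. Among the compounds with values here, this removes the hydroxy, so the step to compound 3 is the one measured change that bears on it. Read backwards, that step points towards the number of compound 2, 4440 nM. Within the data shown here, the tert-butyl is larger, however, and no measured compound tests it, so the expectation remains loose. The expected change is a modest fall towards higher toxicity, a 1.8-fold lower number from compound 3 to compound 4 (0.26 log units; within the scatter). For compound 4 the estimated value is 5000 nM, with an expected range from 1800 nM to 14000 nM.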

Compound 4, half-maximal cytotoxic concentration: 4220 nM
Beside the measured number, compound 4's estimate is 1.2-fold (0.07 log units) above it; the measured number falls inside the stated range.
By their numbers in this assay, from the lowest: compounds 4 and 2 (each within the scatter of the next); then compound 3. At a limit, above all of these: compound 1.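

In this assay, tert-butyl in place of hydroxymethyl on this aromatic carbon gives a 2.1-fold lower number from compound 3 to compound 4 (0.33 log units; beyond the scatter), a modest step of the same size as the earlier one in the opposite direction. The comparison with the methyl group gives a 1.1-fold lower number from compound 2 to compound 4 (0.02 log units; within the scatter), so methyl and tert-butyl cannot be told apart at this place, although tert-butyl has more heavy atoms. Among the three groups compared here, only the hydroxymethyl of compound 3 stands apart, with the higher number and so lower toxicity in this test, and the data shown offer no explanation for this.

From the compounds shown here alone, whether an amine or a carboxylic acid at this place would raise the number further remains open. So does whether a longer chain ending in hydroxy would behave like hydroxymethyl.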